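Replacing methyl by 4-methylpiperazin-1-yl on the sulfonyl sulfur

The source may hold more compounds than are shown below. What is called first, only, known or untested is meant among the compounds shown, and "the series" means these compounds.

Three measured compounds share one core and differ only in the group on a sulfonyl sulfur. In an assay on CHO cells for displacement of a labelled ligand from prostaglandin D2 receptor 2 (Homo sapiens), read by scintillation counting (on this read-out higher numbers stand for weaker inhibition and lower numbers for stronger inhibition), compound 1 `Cc1ccc(S(=O)(=O)NC(C)C)cc1C#Cc1cc(Cl)ccc1OCC(=O)O` gives 3.4 nM. Compound 2 `Cc1ccc(S(=O)(=O)CCO)cc1C#Cc1cc(Cl)ccc1OCC(=O)O` gives 19 nM in this assay, and compound 3 `Cc1ccc(S(C)(=O)=O)cc1C#Cc1cc(Cl)ccc1OCC(=O)O` gives 5 nM in this assay. Compound 3 therefore holds the second highest of the three numbers, within the scatter of compound 1 and beyond it from compound 2. Compound 4 `Cc1ccc(S(=O)(=O)N2CCN(C)CC2)cc1C#Cc1cc(Cl)ccc1OCC(=O)O` is not yet measured; it differs from compound 3 in that (4-methylpiperazin-1-yl in place of methyl on a sulfonyl sulfur). Going by the values given here, two steps bear on this change. The one most like it, a 1.5-fold higher number from compound 1 to compound 3 (0.17 log units; within the scatter), also swaps an amino group on the sulfonyl sulfur for methyl and stayed within the scatter. The other two, a 5.6-fold higher number from compound 1 to compound 2 (0.75 log units; beyond the scatter) and a 3.8-fold lower number from compound 2 to compound 3 (0.58 log units; beyond the scatter), show that a longer chain with a hydroxyl raised the number modestly. The incoming group is larger than isopropylamino, so a small rise at most is expected. Compound 4 is therefore expected to give 8 nM in this assay, between 3 nM and 25 nM, an expected step of a 1.6-fold higher number from compound 3 to compound 4 (0.20 log units; within the scatter).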

Compound 4, inhibition constant: 21 nM
Compound 4: middle estimate off by 2.6-fold (0.42 log units), on the low side, and the stated range covers the measured number.
By their numbers in this assay, from the lowest: compounds 1 and 3 (each within the scatter of the next); then compounds 2 and 4 (each within the scatter of the next).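

In this assay, an amino group on this sulfonyl sulfur no longer matches methyl once it is 4-methylpiperazin-1-yl, with a 4.2-fold higher number from compound 3 to compound 4 (0.62 log units; beyond the scatter) as the result. The nitrogen-linked groups also part from each other here, as a 6.2-fold higher number from compound 1 to compound 4 (0.79 log units; beyond the scatter) shows, so the earlier match between isopropylamino and methyl does not extend to every amino group. With a 1.1-fold higher number from compound 2 to compound 4 (0.04 log units; within the scatter) as the remaining comparison, 4-methylpiperazin-1-yl and 2-hydroxyethyl cannot be told apart, and no measurement shown here accounts for the rise. The compounds leave open whether morpholin-4-yl, piperidin-1-yl or unsubstituted piperazin-1-yl on the sulfonyl sulfur would sit with compound 4 or with compound 3. They also leave open where a small amine such as dimethylamino would fall.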